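Thiophene for chlorophenyl on the cyclopropane of compound 2

The compounds below may be only part of what the source reports. "The series", "measured", "known", "first", "only" and "open" are said of these compounds alone.

Measured compounds:
compound 1, `CC(C)C[C@@H](N)CN(C(=O)[C@@H]1C[C@H]1c1ccccc1)c1ccc(-c2ccccc2)cc1`: 1.8 nM
compound 2, `CC[C@H](C)[C@H](N)CN(C(=O)[C@@H]1C[C@H]1c1cccc(Cl)c1)c1ccc(-c2ccccc2)cc1`: 2200 nM

Two compounds carry numbers in a functional assay for agonist activity at G protein-coupled receptor 88 (Homo sapiens), read by HTRF and cAMP accumulation; on this read-out higher numbers stand for an effect only at larger amounts of compound and lower numbers for an effect already at smaller amounts. Compound 1 gives 1.8 nM, while compound 2 gives 2200 nM, the higher of the two numbers, and the gap between them lies beyond the usual scatter. The two compounds differ in more than one place, so their values say only what they show and no single change can be tied to the gap.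

Compound 3, `CC[C@H](C)[C@H](N)CN(C(=O)[C@@H]1C[C@H]1c1ccsc1)c1ccc(-c2ccccc2)cc1`, has not been measured. It is compound 2 with one change: thiophen-3-yl in place of 3-chlorophenyl on a saturated ring carbon. The group that enters sits on the saturated ring carbon of the three-membered ring, next to the ring atom that bears a large group.

For the measured compounds named here, no measured pair shows this exchange, so the size of the step rests on judgement alone. Compound 3 is expected to move toward lower numbers than compound 2, with a step of a 2.4-fold lower number from compound 2 to compound 3 (0.39 log units; beyond the scatter) in this assay, though a step that stays within the scatter cannot be excluded. The estimate for compound 3 in this assay is 900 nM, with a range from 150 nM to 5000 nM.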

Compound 3, half-maximal effective concentration: 450 nM
Compound 3: the middle estimate sits 2.0-fold (0.30 log units) above what was measured, within the range that was stated.
By their numbers in this assay, from the lowest: compound 1; then compound 3; then compound 2.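

In this assay, for the compounds shown here, the exchange of 3-chlorophenyl for thiophen-3-yl on a saturated ring carbon of the three-membered ring gives a 4.9-fold lower number from compound 2 to compound 3 (0.69 log units; beyond the scatter) and is the first step at this position that can be read on its own. It shows that this position responds to the group it carries and that, with the chlorine gone and a five-membered aromatic ring with 1 hetero atom in place of a six-membered aromatic ring of carbon only, the number falls by a modest step. Nothing measured here bears on why the number moves in this direction.

The exchange changes the ring and removes the chlorine in one step, so the compounds shown leave open how much of the step belongs to each, a question that a plain phenyl group on the same frame of compound 2 would address. They also leave open how other aromatic groups at this position, such as thiophen-2-yl or a pyridine ring, would compare with thiophen-3-yl, and how far the step carries over to the side chain of compound 1.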